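The source may report more compounds than this note shows. Statements on the series, on what has been measured and on what is new or still open speak of the compounds shown alone.

Series values, measured in a functional assay on U-373MG ATCC cells (Homo sapiens) for inhibition, read by colorimetric assay and MTT assay, with a stated time of 72 h (a lower number here means a stronger inhibitor, a higher number a weaker inhibitor), as follows
compound 1 (`C=CCCCCOc1ccccc1-c1cnc(OCCC=C)n1C`) gives 33000 nM
compound 2 (`C=CCCCCOc1ccc(C)cc1-c1cnc(OCCC=C)n1C`) gives 33000 nM
compound 3 (`C=CCCCCOc1cc2ccccc2cc1-c1cnc(OCCC=C)n1C`) gives 27000 nM

Compound 3 stands level with compound 1 and compound 2, all within the scatter. Compound 4 (`C=CCCCCOc1cc2ccccc2cc1-c1cnc(OCCCCC=C)n1C`) carries but-3-en-1-yl in place of vinyl on a saturated chain carbon, two bonds along the chain from an oxygen on an aromatic ring, so (but-3-en-1-yl)oxy becomes (hex-5-en-1-yl)oxy (but-3-en-1-yl in place of vinyl on a saturated chain carbon, two bonds along the chain from an oxygen on an aromatic ring). For the measured compounds named here, the only measured step (no change at the digits printed from compound 1 to compound 2 (within the scatter)) is methyl in place of hydrogen on an aromatic carbon, a different change, and it stays within the scatter. Going by the values given here, no measured step alters this chain, so guidance is weak. In this assay no step beyond the scatter is expected (a 1.1-fold lower number from compound 3 to compound 4 (0.03 log units; within the scatter)). Compound 4 is estimated at 25000 nM with an expected range from 12000 nM to 50000 nM for repeat measurements.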

Compound 4, half-maximal inhibitory concentration: 33000 nM
Estimate against measurement, compound 4: 1.3-fold (0.12 log units) below; low and high end bracket the measured number.
By their numbers in this assay, from the lowest: compounds 3, 1, 2 and 4 (each within the scatter of the next).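

In this assay, for the compounds shown here, the change from (but-3-en-1-yl)oxy to (hex-5-en-1-yl)oxy gives a 1.2-fold higher number from compound 3 to compound 4 (0.09 log units; within the scatter) and is the first measured step at this chain. Adding to this chain on the shared core therefore leaves the number within the scatter, with but-3-en-1-yl in place of vinyl producing no measurable shift. No supporting data bear on this result. From the compounds shown here alone, it remains open whether an amine or a carboxylic acid at the end of this chain, or a chain longer than hex-5-en-1-yl, would move the number beyond the scatter.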